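A few compounds are considered here, and "the series" means these few. Any claim that something is new, unique, unknown or untested is made for them only; others in the source may bear on it.

For the measured compounds named here, in a functional assay on BGC-823 cells (Homo sapiens) for cytotoxicity, read by CCK-8 assay, with a stated time of 72 h (a lower number here means a stronger inhibitor, a higher number a weaker inhibitor), compound 1, `C=CCn1c(=O)/c(=C\c2cc(F)ccc2C)[nH]c(=O)/c1=C\c1ccccc1OC`, gives 1600 nM, which is the higher of the two numbers known so far. Compound 2, `COc1ccccc1/C=c1\c(=O)[nH]/c(=C/c2ccccc2Cl)c(=O)n1C`, gives 300 nM in this assay, a result beyond the scatter from that of compound 1, and compound 3, `COc1ccccc1/C=c1/[nH]c(=O)/c(=C\c2cccc(Cl)c2Cl)[nH]c1=O`, gives "not active" (no number reported) in this assay, a result reported without a number. Compound 4, `C=CCn1c(=O)/c(=C\c2ccc(Cl)c(Cl)c2)[nH]c(=O)/c1=C\c1ccccc1OC`, is not yet measured. It differs from compound 1 by 3,4-dichlorophenyl in place of 5-fluoro-2-methylphenyl on a double-bonded chain carbon bound to an aromatic carbon. Going by the values given here, no measured pair here shows the effect of this change, so the direction is uncertain, and only a step of modest size is expected, a 1.3-fold lower number from compound 1 to compound 4 (0.12 log units; within the scatter), with the lower number as the slightly more likely outcome. For compound 4 the estimate in this assay is 1200 nM, with a range from 400 nM to 4000 nM.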

Compound 4, half-maximal inhibitory concentration: "not active" (no number reported)
Compound 4 has no reported number here; no gap can be computed for the estimate.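

For the compounds shown here, compound 4 carries no number in this assay, so no step from compound 1 to compound 4 can be read. No measured evidence bears on this result. The compounds shown leave open how much activity 3,4-dichlorophenyl gives relative to 5-fluoro-2-methylphenyl on the shared core.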